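Ethoxy in place of isopropyl: notes on compound 3

The source may hold more compounds than are shown below. What is called first, only, known or untested is meant among the compounds shown, and "the series" means these compounds.

Going by the values given here, in a functional assay on MLM cells (Homo sapiens) for cytotoxicity, using microsomes (a higher number here means that more compound is needed for the effect, a lower number that less compound is needed), compound 2 `COc1cc(/C=C\c2ccc(C(C)C)cc2)cc(OC)c1OC` gives 7 uM as the highest of the two numbers so far. Compound 1 `CCOc1ccc(/C=C/c2cc(OC)c(OC)c(OC)c2)cc1` gives 2.2 uM as the lower number, a gap beyond the scatter. Compound 3 `CCOc1ccc(/C=C\c2cc(OC)c(OC)c(OC)c2)cc1` carries ethoxy in place of isopropyl on an aromatic carbon, para to a large group (ethoxy in place of isopropyl on an aromatic carbon). Among the compounds with values here, no measured step covers this change, so in this assay no step beyond the scatter is expected, with a slight lean to a lower number. The estimated move is a 1.8-fold lower number from compound 2 to compound 3 (0.24 log units; within the scatter) and stays within the scatter. Compound 3 is estimated at 4 uM with an expected range of 1.2 uM to 13 uM in this measurement.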

Compound 3, concentration for half-maximal effect: 2.9 uM
The estimate for compound 3 lay 1.4-fold (0.14 log units) above the measured number; low and high end bracket the measured number.
By their numbers in this assay, from the lowest: compounds 1 and 3 (each within the scatter of the next); then compound 2.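

Compound 3 links compounds 1 and 2, which differ in more than one place, and so divides their gap in this assay. With the double bond drawn Z on both sides, ethoxy in place of isopropyl on an aromatic carbon, para to a large group, gives a 2.4-fold lower number from compound 2 to compound 3 (0.38 log units; beyond the scatter), while changing the drawn configuration gives only a 1.3-fold higher number from compound 1 to compound 3 (0.12 log units; within the scatter). The second step isolates a single feature: the fact that compounds 1 and 3 differ only in the configuration as drawn

Open, as far as these compounds go, is how a longer chain such as butoxy, a hydroxyl or an amine would read at this position. Also open, from the compounds shown here alone, is whether the double bond configuration matters as little with isopropyl in place of ethoxy.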